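The compounds below may be only part of what the source reports. "The series", "measured", "known", "first", "only" and "open" are said of these compounds alone.

Compound 1 `CCn1cc(COc2cc(O)c3c(c2)O[C@H](c2ccc(OC)c(O)c2)C/C3=N\O)nn1`: 3140 nM in a functional assay on RAW264.7 cells (Mus musculus) for inhibition, read by Griess assay, with stated times of 2 h and 24 h; a higher number here means a weaker inhibitor, a lower number a stronger inhibitor.
Compound 2 `COc1ccc([C@@H]2CC(=O)c3c(O)cc(OCc4cn(Cc5cccc(Cl)c5)nn4)cc3O2)cc1O`: 18200 nM.
Compound 3 `COc1ccc([C@@H]2CC(=O)c3c(O)cc(OCc4cn(Cc5ccccc5Cl)nn4)cc3O2)cc1O`: 6140 nM.

Among these three numbers, compound 3 holds the second highest; its gap to compound 1 lies within the scatter, whereas its gap to compound 2 lies beyond it. Compound 4 `COc1ccc([C@@H]2CC(=O)c3c(O)cc(OCc4cn(Cc5cccc(C(F)(F)F)c5)nn4)cc3O2)cc1O` differs from compound 3 by 3-(trifluoromethyl)phenyl in place of 2-chlorophenyl on a saturated chain carbon bound to an aromatic nitrogen. Among the measured compounds shown here, only one measured step touches the same place, a swap of one chlorophenyl for another on that carbon: a 3.0-fold lower number from compound 2 to compound 3 (0.47 log units; beyond the scatter). Compound 4 carries a 3-substituted ring, as compound 2 does, rather than the 2-chlorophenyl of compound 3, so the number is expected to move back upward, by roughly a 2.0-fold higher number from compound 3 to compound 4 (0.29 log units; within the scatter), a modest step. Compound 4 is therefore estimated at 12000 nM, within a range of 4000 nM to 35000 nM.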

Compound 4, half-maximal inhibitory concentration: 19900 nM
For compound 4 the middle estimate is 1.7-fold (0.22 log units) below the measured one, within the range that was stated.
By their numbers in this assay, from the lowest: compounds 1 and 3 (each within the scatter of the next); then compounds 2 and 4 (each within the scatter of the next).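

In this assay, trifluoromethyl in place of chloro on the aromatic carbon gives a 1.1-fold higher number from compound 2 to compound 4 (0.04 log units; within the scatter), so 3-chlorophenyl and 3-(trifluoromethyl)phenyl cannot be told apart at this place. The change from 2-chlorophenyl to 3-(trifluoromethyl)phenyl gives a 3.2-fold higher number from compound 3 to compound 4 (0.51 log units; beyond the scatter), which leaves compound 3 apart from both compounds with a 3-substituted ring. No measurement here explains this difference.

On these data alone, it remains open what a plain phenyl, or a ring carrying an amine or a carboxylic acid, would give on the same carbon.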